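Iodo to Nitro on a Shared Core: a Forecast

This account rests on a few compounds, and the source may have more. Where it says the series, first, only, none or still open, it means among the compounds named here.

The measured compounds, each tested in a functional assay on U-87MG ATCC cells (Homo sapiens) for cytotoxicity, read by MTT assay, with a stated time of 48 h; a lower number here means a stronger inhibitor, a higher number a weaker inhibitor:
Compound 1 `CC(=NNC(=S)Nc1ccc(I)cc1)c1ccccn1`; compound 1 gives 59 nM
Compound 2 `C/C(=N/NC(=S)Nc1ccc(I)cc1)c1ccccn1`; compound 2 gives 59 nM
Compound 3 `C/C(=N\NC(=S)Nc1ccc(I)cc1)c1ccccn1`; compound 3 gives 59 nM

Compound 2 stands level with compounds 1 and 3. The steps of no change at the digits printed from compound 1 to compound 2 (within the scatter), no change at the digits printed from compound 1 to compound 3 (within the scatter) and no change at the digits printed from compound 2 to compound 3 (within the scatter) show no change within the scatter, which accords with the fact that one of compounds 1 and 2 is drawn with a defined configuration and the other without, at the place where they differ, the fact that one of compounds 1 and 3 is drawn with a defined configuration and the other without, at the place where they differ and the fact that compounds 2 and 3 differ only in the configuration as drawn: the three compounds share all atoms and bonds and differ only in how the double bond is drawn.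

Compound 4 `C/C(=N/NC(=S)Nc1ccc([N+](=O)[O-])cc1)c1ccccn1` has not been measured. It differs from compound 2 by nitro in place of iodo on an aromatic carbon. Among the compounds with values here, none of the measured steps involves a change of this kind; they are all drawing-only steps of no size, and so they give no guide to the direction or size of the step in this assay. Within the data shown here, the only anchor is compound 2, which gives 59 nM. The expected step is therefore a 1.5-fold higher number from compound 2 to compound 4 (0.18 log units; within the scatter), held close to no change but with wide uncertainty. Compound 4 is estimated at 90 nM, within a range from 15 nM to 500 nM.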

Compound 4, half-maximal inhibitory concentration: 160 nM
Compound 4: the middle estimate sits 1.8-fold (0.25 log units) below what was measured, within the range that was stated.
By their numbers in this assay, from the lowest: compounds 1, 2 and 3 (each within the scatter of the next); then compound 4.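

In this assay, nitro in place of iodo on an aromatic carbon, para to a large group, gives a 2.7-fold higher number from compound 2 to compound 4 (0.43 log units; beyond the scatter) and is the only step among these compounds that lies beyond the scatter. It shows that the number at this position responds to the group attached there, although the step is modest and compound 4 still gives 160 nM in the nanomolar range. The earlier compounds differed only in how the double bond was drawn and could not show this, and nothing in the evidence at hand bears on why this exchange raises the number.

From the compounds shown here alone, whether the higher number is particular to nitro or would also appear with an amine, a methyl or a carboxylic acid at this place remains open. Also open, going by these compounds, is whether the same exchange would give a step of similar size elsewhere on the shared core.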